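The source may hold more compounds than are shown below. What is called first, only, known or untested is meant among the compounds shown, and "the series" means these compounds.

Measured so far:
- compound 1 `CCc1ccc(-c2nc3c(c(C)nn3-c3ccccc3)c(-c3ccccc3OC)c2C#N)cc1` gives 7800 nM
- compound 2 `Cc1ccc(-c2nc3c(c(C)nn3-c3ccccc3)c(-c3ccccc3O)c2C#N)cc1` gives 26000 nM

Both numbers come from a physicochemical assay for solubility, read by spectrophotometry, in phosphate buffer, with a stated time of 18 h, at pH 7.4; a higher number here means a more soluble compound, a lower number a less soluble compound. Among the measured compounds shown here, compound 2 stands highest of the two; compound 1 is the only neighbour and sits well below it, a gap beyond the usual scatter. For the measured compounds named here, no single-point step between measured compounds is available, as compound 1 and compound 2 differ in two places.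

Compound 3 `Cc1nn(-c2ccccc2)c2nc(-c3ccc(C(F)(F)F)cc3)c(C#N)c(-c3ccccc3O)c12` is not yet measured. It differs from compound 2 by trifluoromethyl in place of methyl on an aromatic carbon. For compound 3 a move downward in this assay is expected, of a size just beyond the scatter, as a 2.6-fold lower number from compound 2 to compound 3 (0.41 log units; beyond the scatter). The estimate for compound 3 is 10000 nM, in the range 4000 nM to 26000 nM.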

Compound 3, solubility: 3500 nM
Compound 3: middle estimate off by 2.9-fold (0.46 log units), on the high side; the whole stated range lies above it.
By their numbers in this assay, from the lowest: compound 3; then compound 1; then compound 2.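

In this assay, among the compounds shown here, the change from 4-methylphenyl to 4-(trifluoromethyl)phenyl gives a 7.4-fold lower number from compound 2 to compound 3 (0.87 log units; beyond the scatter) as the first one-place step. The number at this position, para to a large group, therefore moves with the group it carries, which compounds differing in two places could not show. Nothing measured here bears on the reason for the drop. On these data alone, only methyl and trifluoromethyl are compared at this position, so the outcome with an amine, a carboxylic acid or a longer chain remains open. The separate contributions of the two differences between compound 1 and compound 2 also remain unresolved.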